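This account rests on a few compounds, and the source may have more. Where it says the series, first, only, none or still open, it means among the compounds named here.

Measured compounds:
- Compound 3, `CCNC(=O)c1noc(-c2cc(C(C)C)c(O)cc2O)c1-c1cc(CNC(C)C)no1`: 38 nM
- Compound 1, `CCNC(=O)c1noc(-c2cc(C(C)C)c(O)cc2O)c1-c1cc(COCC(N)=O)no1`: "not determined" (no result reported)
- Compound 2, `CCNC(=O)c1noc(-c2cc(C(C)C)c(O)cc2O)c1-c1cc(CN)no1`: "not determined" (no result reported)

In a functional assay on A2780 cells (Homo sapiens) for inhibition (on this read-out higher numbers stand for weaker inhibition and lower numbers for stronger inhibition), compound 3 gives 38 nM, the only number among these three; compound 1 and compound 2 carry no result, so nothing can be said of how they compare. Compound 4, `CCNC(=O)c1noc(-c2cc(C(C)C)c(O)cc2O)c1-c1cc(CN2CCCC2)no1`, is not yet measured. It differs from compound 3 in one place: pyrrolidin-1-yl in place of isopropylamino on a saturated chain carbon bound to an aromatic carbon. Within the data shown here, no step between two measured compounds is available to guide this change, so the expectation rests on compound 3 alone. Compound 4 is expected to stay close to compound 3, with a step of a 1.1-fold higher number from compound 3 to compound 4 (0.02 log units; within the scatter) that lies within the usual scatter. The estimate for compound 4 in this assay is 40 nM, with a likely range from 15 nM to 120 nM.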

Compound 4, half-maximal inhibitory concentration: 55 nM
The estimate for compound 4 lay 1.4-fold (0.14 log units) below the measured number; the range from low to high includes it.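

In this assay, putting pyrrolidin-1-yl in place of isopropylamino gives a 1.4-fold higher number from compound 3 to compound 4 (0.16 log units; within the scatter). For this pair, then, the saturated chain carbon bound to an aromatic carbon carries either an open-chain amine or a five-membered ring, and the hydrogen-bond donor counted on isopropylamino can go without a change beyond the scatter. Nothing available explains this result.

On these data alone, whether the same tolerance holds for a larger ring such as piperidine or morpholine remains open. So does the outcome with a carboxylic acid at this place.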